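Swapping the enone end on a pyrazolopyrimidine chalcone

The compounds below may be only part of what the source reports. "The series", "measured", "known", "first", "only" and "open" are said of these compounds alone.

Of the compounds shown here, three sharing one fused core have been measured for antiproliferative activity in a functional assay on A549 cells (Homo sapiens) for antiproliferative activity, read by MTT assay, with a stated time of 24 h; on this read-out lower numbers stand for stronger inhibition and higher numbers for weaker inhibition. Compound 1 `COc1ccc(C(=O)/C=C/c2cc(-c3cc(OC)c(OC)c(OC)c3)n3nc(-c4ccccc4)cc3n2)cc1` gives 14600 nM, compound 3 `COc1cc(-c2cc(C(=O)/C=C/c3ccccc3)nc3cc(-c4ccccc4)nn23)cc(OC)c1OC` gives 18000 nM, and compound 2 `COc1ccc(/C=C/C(=O)c2cc(-c3ccc(OC)c(OC)c3)n3nc(-c4ccccc4)cc3n2)cc1` gives 19300 nM. Compound 2 thus stands at the highest of the three numbers, but its nearest neighbour compound 3 and its farthest neighbour compound 1 both lie within the scatter of it, so no order among the three can be claimed.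

The step to compound 4 `COc1ccc(-c2cc(/C=C/C(=O)c3ccccc3)nc3cc(-c4ccccc4)nn23)cc1OC` is described by 2-benzoylethenyl in place of (2-(4-methoxyphenyl)ethenyl)carbonyl on an aromatic carbon. Among the measured compounds shown here, one measured step bears on it: a 1.2-fold higher number from compound 1 to compound 3 (0.09 log units; within the scatter). That step likewise exchanged the enone arm attached to the core for one carrying an unsubstituted phenyl and a changed orientation of the carbonyl, and it produced no movement beyond the scatter. On that basis, and because compound 2 already sits at 19300 nM, the change to compound 4 is expected to leave the number roughly where it is.

Compound 4 is therefore estimated at 20000 nM in this assay, with a range from 10000 nM to 40000 nM, meaning an expected step of a 1.0-fold higher number from compound 2 to compound 4 (0.02 log units; within the scatter).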

Compound 4, half-maximal inhibitory concentration: 10700 nM
Estimate against measurement, compound 4: 1.9-fold (0.27 log units) above, and the stated range covers the measured number.
By their numbers in this assay, from the lowest: compounds 4, 1, 3 and 2 (each within the scatter of the next).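

Among the compounds shown here, the new step is the first reading of this change on the 3,4-dimethoxyphenyl compounds: in this assay, the exchange of (2-(4-methoxyphenyl)ethenyl)carbonyl for 2-benzoylethenyl, on the aromatic carbon next to the ring nitrogen, gives a 1.8-fold lower number from compound 2 to compound 4 (0.26 log units; within the scatter). Set beside a 1.2-fold higher number from compound 1 to compound 3 (0.09 log units; within the scatter), which was read on the compounds with the third methoxy group, it shows that the arm at this carbon has now been exchanged in two forms on two different backgrounds, and neither step leaves the scatter, so these four compounds give no sign that the way round the enone arm runs, or the presence of its 4-methoxyphenyl ring, sets the number here. No independent evidence is available to account for this result.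

Because the step from compound 2 to compound 4 alters the direction of the arm and takes away the methoxy group in one move, the compounds shown cannot separate the two changes. They also leave open whether the terminal phenyl ring of the arm would tolerate a morpholine or a carboxylic acid, or whether a saturated propanone chain could stand in place of the enone at this carbon.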